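Azole and benzoyl swaps in a breast-cancer cell series

The compounds below may be only part of what the source reports. "The series", "measured", "known", "first", "only" and "open" are said of these compounds alone.

All numbers below come from a functional assay on MDA-MB-231 cells (Homo sapiens) for inhibition, read by sulforhodamine B assay, tested at 10 uM; a lower number here means less inhibition, a higher number more inhibition at the concentration tested (going by the name of the read-out); the measured compounds are:
compound 1 `CN(C)c1ccc(C2CC(c3ccc(-n4cncn4)cc3)=NN2C(=O)c2cc(Cl)cc(Cl)c2)cc1`: 9.4%
compound 2 `CN(C)c1ccc(C2CC(c3ccc(-n4cncn4)cc3)=NN2C(=O)c2ccc(C(F)(F)F)cc2)cc1`: 16.7%
compound 3 `CN(C)c1ccc(C2CC(c3ccc(-n4ccnc4)cc3)=NN2C(=O)c2cc(Cl)cc(Cl)c2)cc1`: 48.8%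

Compound 1 and compound 2 share the core of compound 1 and differ only by 4-(trifluoromethyl)phenyl in place of 3,5-dichlorophenyl on a carbonyl carbon; this change reads as a number 7.3 percentage points higher from compound 1 to compound 2 (within the scatter), so the two values are not distinguishable. Compound 3 differs from compound 1 by 1H-imidazol-1-yl in place of 1H-1,2,4-triazol-1-yl on an aromatic carbon, and that step is a number 39.4 percentage points higher from compound 1 to compound 3 (beyond the scatter). Compound 3 is the highest of the three, its gaps to compound 1 and compound 2 both lying beyond the scatter.

Compound 4 `CN(C)c1ccc(C2CC(c3ccc(-n4ccnc4)cc3)=NN2C(=O)c2ccc(C(F)(F)F)cc2)cc1` has not yet been measured. It differs from compound 3 by 4-(trifluoromethyl)phenyl in place of 3,5-dichlorophenyl on a carbonyl carbon, the same change already seen from compound 1 to compound 2, made at an identical place. Since the earlier instance gave only a number 7.3 percentage points higher from compound 1 to compound 2 (within the scatter), compound 4 is expected to move by about a number 6.2 percentage points higher from compound 3 to compound 4 (within the scatter) from compound 3, staying within scatter. Compound 4 is thus estimated at 55%, with the likely range 35% to 72%, resting on a single prior example only.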

Compound 4, a percentage reported as inhibition, at one concentration (the size of the read-out at that concentration, not a potency): 17.9%
Compound 4: middle estimate off by 37.1 percentage points, on the high side; the measured number lies below the stated range.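

With 1H-imidazol-1-yl on the aromatic carbon, 4-(trifluoromethyl)phenyl in place of 3,5-dichlorophenyl gives a number 30.9 percentage points lower from compound 3 to compound 4 (beyond the scatter), so this change does not carry over from the 1H-1,2,4-triazol-1-yl compounds: the same change on two cores in this assay, a number 7.3 percentage points higher (within the scatter) from compound 1 to compound 2 and a number 30.9 percentage points lower (beyond the scatter) from compound 3 to compound 4, 38.2 percentage points apart, beyond the scatter of two such steps. The azole change likewise depends on the group on the carbonyl carbon, giving only a number 1.2 percentage points higher from compound 2 to compound 4 (within the scatter) once 4-(trifluoromethyl)phenyl is present: the same change on two cores in this assay, a number 39.4 percentage points higher (beyond the scatter) from compound 1 to compound 3 and a number 1.2 percentage points higher (within the scatter) from compound 2 to compound 4, 38.2 percentage points apart, beyond the scatter of two such steps. The two changes therefore do not act independently in these four compounds, with compound 3 alone standing apart from the rest, but this is a single set of four compounds in this assay at one concentration, and it shows neither why the dependence arises nor whether it extends to other groups.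

The compounds shown leave open whether the value of compound 3 needs both chlorines, which a plain phenyl or a 4-chlorophenyl on the carbonyl carbon, paired with 1H-imidazol-1-yl, would test. Also open, on these data alone, are how a 1H-pyrazol-1-yl in place of the azole would behave and what part the dimethylamino group plays.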